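Triazolylmethyl spirooxindole series: antiproliferative read-out, step to compound 4

The source may report more compounds than this note shows. Statements on the series, on what has been measured and on what is new or still open speak of the compounds shown alone.

Compound 1 `N#CC1=C(N)Oc2c(c3nc4ccccc4nc3c3ccccc23)C12C(=O)N(Cc1cnnn1-c1ccccc1Cl)c1ccccc12`: > 50000 nM
Compound 2 `Cc1ccc(-n2nncc2CN2C(=O)C3(C(C#N)=C(N)Oc4c3c3nc5ccccc5nc3c3ccccc43)c3ccccc32)cc1Cl`: > 50000 nM
Compound 3 `N#CC1=C(N)Oc2c(N)cc3nc4ccccc4nc3c2C12C(=O)N(Cc1cnnn1-c1ccc(F)cc1)c1ccccc12`: > 50000 nM

Among the compounds with values here, in an ADME assay on HUVEC cells (Homo sapiens) for antiproliferative activity, read by MTT assay, with a stated time of 48 h (on this read-out lower numbers stand for stronger inhibition and higher numbers for weaker inhibition), every measured value so far is a limit of the assay and not a number. Compound 1 gives only the limit > 50000 nM. Compound 2 likewise gives only the limit > 50000 nM. Going by these compounds, compound 3 stands at the same limit, > 50000 nM, so its position on the scale is unknown beyond that.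

Within the data shown here, the single measured step, a step that the two limits leave unreadable from compound 1 to compound 2, cannot be read because both its ends sit at the limit of > 50000 nM in this assay, at which 3 of the 3 values shown sit. It therefore yields no size that could be carried over.

Compound 4 `CCc1cccc(C)c1-n1nncc1CN1C(=O)C2(C(C#N)=C(N)Oc3c(N)cc4nc5ccccc5nc4c32)c2ccccc21` differs from compound 3 only on the triazole: 2-ethyl-6-methylphenyl in place of 4-fluorophenyl on an aromatic nitrogen. Among the measured compounds shown here, no measured step concerns an exchange of this kind, and the one step that exists is unreadable. Nothing in the series suggests that this change would pull the value down from the limit, so compound 4 is expected to remain at the limit as well, and the step that the limit leaves unreadable from compound 3 to compound 4 is expected to be none that can be read. The estimate for compound 4 is 80000 nM, between 30000 nM and 300000 nM, with the measurement most likely to be reported as a limit again.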

Compound 4, half-maximal inhibitory concentration: > 50000 nM
Compound 4: a limit, no number (the forecaster's own chance of this, stated with the estimate: 85%); the middle value lies beyond the limit too.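

Compound 3 and compound 4 give no readable step, because each stands at a limit of the assay and not at a number: the limit of > 50000 nM in this assay, at which 4 of the 4 values shown sit.

The compounds shown leave open how far beyond that limit each one lies in this assay, and whether any other group on the aromatic nitrogen, or any change to the shared core, would give a measurable value.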